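The compounds below may be only part of what the source reports. "The series", "measured", "known", "first", "only" and "open" are said of these compounds alone.

Measured compounds in an ADME assay on the whole organism with Oryza sativa as the target, tested at 0.1 uM; on this read-out higher numbers stand for a weaker effect at the one concentration tested and lower numbers for a stronger effect:
- compound 1, `CCCc1ccc(NC(=O)N[C@H](C)c2ccccc2)cc1`: 33%
- compound 2, `CCCCc1ccc(NC(=O)N[C@H](C)c2ccccc2)cc1`: 100%
- compound 3, `CCCCCc1ccc(NC(=O)N[C@H](C)c2ccccc2)cc1`: 100%

Compound 3 is level with compound 2 at the digits printed, and together these two carry the highest of the three numbers, so the weakest effect at the single concentration tested. The step of a number 67 percentage points higher from compound 1 to compound 3 (beyond the scatter) is large; the step of no change at the digits printed from compound 2 to compound 3 (within the scatter) is within the scatter.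

Compound 4, `CCOC(=O)c1ccc(NC(=O)N[C@H](C)c2ccccc2)cc1`, has not yet been measured. It differs from compound 3 by ethoxycarbonyl in place of pentyl on an aromatic carbon. Among the compounds with values here, none of the measured steps touches the kind of group at this aromatic carbon: a number 67 percentage points higher from compound 1 to compound 2 (beyond the scatter) and a number 67 percentage points higher from compound 1 to compound 3 (beyond the scatter) only lengthen the chain, and no change at the digits printed from compound 2 to compound 3 (within the scatter) lengthens it further without effect. They show that a small change at this position can shift the read-out strongly, but they give no direction for trading the chain for ethoxycarbonyl. Compound 4 is therefore expected near the middle of the observed spread, with a wide range: an estimated 65%, between 25% and 100%, meaning an expected step of a number 35 percentage points lower from compound 3 to compound 4 (beyond the scatter).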

Compound 4, a percentage reported as activity, at one concentration (the size of the read-out at that concentration, not a potency): 101%
Compound 4: the middle estimate sits 36 percentage points below what was measured, and the stated range ends below it.
By their numbers in this assay, from the lowest: compound 1; then compounds 2, 3 and 4 (each within the scatter of the next).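

In this assay, within the data shown here, the first change in the kind of group at this aromatic carbon, ethoxycarbonyl in place of a saturated chain, gives a number 1 percentage points higher from compound 3 to compound 4 (within the scatter) and a number 1 percentage points higher from compound 2 to compound 4 (within the scatter) so compound 4 reads with the pentyl and butyl compounds despite the carbonyl and the oxygen atoms it brings. Against the propyl compound the picture is different, with a number 68 percentage points higher from compound 1 to compound 4 (beyond the scatter) so among these four compounds only compound 1 stands apart, and the high level is not confined to longer saturated chains. No measurement on hand accounts for this result.

On these data alone, whether a carboxylic acid, an amine or a methoxycarbonyl at this carbon would move the read-out towards that of compound 1 stays open. So does the reading for a shorter chain such as ethyl.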